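This account rests on a few compounds, and the source may have more. Where it says the series, first, only, none or still open, it means among the compounds named here.

Four compounds sharing the same core are set side by side here. Compound 1 `CC1(c2ccccc2)CC(=O)N(CC(=O)N2CCN(c3ccc(Cl)cc3)CC2)C1=O` carries a 4-chlorophenyl on the ring nitrogen of the six-membered ring with two nitrogens; in a functional assay on the whole organism (strain CD-1) with Mus musculus as the target, with a stated time of 2 h (on this read-out lower numbers stand for an effect already at smaller amounts and higher numbers for an effect only at larger amounts of compound), compound 1 gives 300 mg/kg. Compound 2 `COc1cccc(N2CCN(C(=O)CN3C(=O)CC(C)(c4ccccc4)C3=O)CC2)c1` is reported in this assay as "not active" (no number reported), and compound 3 `COc1ccccc1N1CCN(C(=O)CN2C(=O)CC(C)(c3ccccc3)C2=O)CC1` likewise as "not active" (no number reported). Going by the values given here, compound 3 therefore stands without a single number, and one further entry, compound 2, also lacks one, so no step between measured compounds can be given. Compound 4 `CC1(c2ccccc2)CC(=O)N(CC(=O)N2CCN(c3ccc(F)cc3)CC2)C1=O` is the one still to be tested. The change from compound 3 to compound 4 is 4-fluorophenyl in place of 2-methoxyphenyl on an amine nitrogen in a ring. Among the compounds with values here, with no measured step to lean on, only the number for compound 1 and the two entries without a number, a step in this assay of uncertain size is expected, if any, in the direction of an effect appearing where compound 3 showed none. Compound 4 is therefore estimated at 300 mg/kg, in a range from 100 mg/kg to 1000 mg/kg, with a real chance that only an entry without a number will again be reported.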

Compound 4, minimum effective dose: "not active" (no number reported)
Compound 4 has no reported number here, so the estimate cannot be set against anything.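

Compound 3 and compound 4 are both reported as "not active" in this assay, so no step can be read between them, and no supporting evidence bears on this result. Going by these compounds, how much the group on the ring nitrogen matters stays open, with only compound 1 giving a number, 300 mg/kg.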